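Compound 3 to compound 4: one group swapped

This account rests on a few compounds, and the source may have more. Where it says the series, first, only, none or still open, it means among the compounds named here.

compound 1 `O=C(N[C@H]1CN(S(=O)(=O)c2ccccc2)C[C@@H]1C(=O)N[C@H]1CCCNC1)c1cc(-c2ccc(Cl)cc2)on1`: 12000 nM
compound 2 `Cc1ccc2[nH]c(C(=O)N[C@H]3CN(S(=O)(=O)c4ccccc4)C[C@]3(C)C(=O)N[C@H]3CCCNC3)cc2c1`: 271000 nM
compound 3 `O=C(N[C@H]1CN(S(=O)(=O)c2ccccc2)C[C@@H]1C(=O)N1C[C@H]2CCNC[C@H]21)c1cc(-c2ccccc2Cl)on1`: 265000 nM

These values come from a physicochemical assay for solubility, at pH 7.4; a higher number here means a more soluble compound, a lower number a less soluble compound. Compound 3 lies within the usual scatter of compound 2, while compound 1 sits far lower, well beyond that scatter.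

Compound 4 `O=CN1CCC[C@H](NC(=O)[C@H]2CN(S(=O)(=O)c3ccccc3)C[C@@H]2NC(=O)c2cc(-c3ccccc3Cl)on2)C1` differs from compound 3 in one place: a group of 9 heavy atoms (6 carbon, 2 nitrogen, 1 oxygen; one six-membered non-aromatic ring with 1 hetero atom) in place of a group of 8 heavy atoms (6 carbon, 2 nitrogen; one four-membered non-aromatic ring with 1 hetero atom, one six-membered non-aromatic ring with 1 hetero atom), on a carbonyl carbon. Within the data shown here, no measured pair isolates this change, so any forecast is uncertain. Compound 1, at 12000 nM, also carries one six-membered non-aromatic ring with 1 hetero atom, which points to a fall beyond the scatter. The expected change is a 6.6-fold lower number from compound 3 to compound 4 (0.82 log units; beyond the scatter). For compound 4 the estimate is 40000 nM, with an expected range of 10000 nM to 150000 nM.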

Compound 4, solubility: 4500 nM
Compound 4: the middle estimate sits 8.9-fold (0.95 log units) above what was measured, outside the stated range (below it).
By their numbers in this assay, from the lowest: compound 4; then compound 1; then compounds 3 and 2 (each within the scatter of the next).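

The measurement in this assay records a 59-fold lower number from compound 3 to compound 4 (1.77 log units; beyond the scatter) when the group with a four-membered and a six-membered non-aromatic ring gives way to the group with one six-membered non-aromatic ring. Among these compounds, this is the first change in one place to be read, and it shows that the group on this carbonyl carbon can move the value far beyond the scatter. No measurement available here explains the size of this step.

The step changes the ring count and adds an oxygen together, so the compounds shown do not separate these two differences. On these data alone, whether an open-chain amine on the same carbonyl carbon would sit nearer compound 3 or compound 4 also stays open.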